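Bromo to Fluoro: Expecting Little Change in Cell Inhibition

The source may report more compounds than this note shows. Statements on the series, on what has been measured and on what is new or still open speak of the compounds shown alone.

Compound 1, `CCOc1ccc(C(=O)/C=C/c2c(/C=C/c3ccc(OC)cc3)cc(OC)cc2OC)cc1`: 8 ug/mL
Compound 2, `COc1ccc(/C=C/c2cc(OC)cc(OC)c2/C=C/C(=O)c2ccc(C)c(C)c2)cc1`: 0.2 ug/mL
Compound 3, `COc1ccc(/C=C/c2cc(OC)cc(OC)c2/C=C/C(=O)c2ccc(Br)cc2)cc1`: 12.9 ug/mL

These three compounds were tested in a functional assay on HepG2 cells (Homo sapiens) for antiproliferative activity, read by MTT assay, with a stated time of 48 h; on this read-out higher numbers stand for weaker inhibition and lower numbers for stronger inhibition. Compound 3 stands highest of the three numbers, but not clearly apart from compound 1: a 1.6-fold higher number from compound 1 to compound 3 (0.21 log units; within the scatter), whereas a 65-fold higher number from compound 2 to compound 3 (1.81 log units; beyond the scatter).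

Compound 4, `COc1ccc(/C=C/c2cc(OC)cc(OC)c2/C=C/C(=O)c2ccc(F)cc2)cc1`, is not yet measured and differs from compound 3 in one place: fluoro in place of bromo on an aromatic carbon. The two large measured steps, a 40-fold lower number from compound 1 to compound 2 (1.60 log units; beyond the scatter) and a 65-fold higher number from compound 2 to compound 3 (1.81 log units; beyond the scatter), replace the whole group on the carbonyl carbon. Among the measured compounds shown here, the only step that swaps one substituent on the aromatic carbon for another, a 1.6-fold higher number from compound 1 to compound 3 (0.21 log units; within the scatter), stayed within the scatter, and no measured step exchanges bromo for fluoro. A step within the scatter is therefore expected, a 1.3-fold lower number from compound 3 to compound 4 (0.11 log units; within the scatter). Compound 4 is estimated at 10 ug/mL, within 3 ug/mL to 30 ug/mL.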

Compound 4, half-maximal inhibitory concentration: 12.2 ug/mL
The estimate for compound 4 lay 1.2-fold (0.09 log units) below the measured number, and the stated range covers the measured number.
By their numbers in this assay, from the lowest: compound 2; then compounds 1, 4 and 3 (each within the scatter of the next).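

In this assay, among the compounds shown here, the first direct exchange of bromo for fluoro on the aromatic carbon para to a large group gives a 1.1-fold lower number from compound 3 to compound 4 (0.02 log units; within the scatter) and so leaves the number unmoved. Replacing ethoxy with fluoro at that place gives a 1.5-fold higher number from compound 1 to compound 4 (0.18 log units; within the scatter) as well, while a 61-fold higher number from compound 2 to compound 4 (1.79 log units; beyond the scatter) shows that 3,4-dimethylphenyl stands as far from 4-fluorophenyl as from 4-bromophenyl. Nothing measured here explains these differences.

On these data alone, whether an amine or a carboxylic acid at this place would stay with these groups or move towards compound 2 remains open.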